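The source may hold more compounds than are shown below. What is called first, only, known or untested is meant among the compounds shown, and "the series" means these compounds.

Measured compounds:
compound 1 `COc1ncc(N2CCc3ncnc(O[C@H]4CCN(C(=O)C5CCOCC5)C4)c3C2)cc1C` – 4150 nM
compound 2 `COc1ccc(N2CCc3ncnc(-c4cccc(OC5CCN(C(C)=O)CC5)c4)c3C2)cn1` – > 9100 nM

Going by the values given here, in an ADME assay on isolated protein for inhibition of phosphatidylinositol 4,5-bisphosphate 3-kinase catalytic subunit beta isoform (Homo sapiens), read by Kinase-Glo, with a stated time of 60 min (a higher number here means a weaker inhibitor, a lower number a stronger inhibitor), compound 1 gives 4150 nM, the only number among the values shown. Compound 2 gives > 9100 nM, which is a limit of the assay (the limit of > 9100 nM in this assay, at which 1 of the 2 values shown sits). Compound 3 `COc1ncc(N2CCc3ncnc(O[C@H]4CCN(C(=O)C5CCOCC5)C4)c3C2)cc1C(F)(F)F` differs from compound 1 in one place: trifluoromethyl in place of methyl on an aromatic carbon. Among the compounds with values here, no step between two measured compounds is available for comparison, so for this change he expects only a small step, if any beyond the scatter, and in an uncertain direction; the step he estimates a 1.1-fold higher number from compound 1 to compound 3 (0.04 log units; within the scatter) stays close to no change. Compound 3 is therefore estimated at 4500 nM, within a range of 1500 nM to 13000 nM.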

Compound 3, half-maximal inhibitory concentration in the phosphatidylinositol 4,5-bisphosphate 3-kinase catalytic subunit beta isoform assay: 1330 nM
Estimate against measurement, compound 3: 3.4-fold (0.53 log units) above; the whole stated range lies above it.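

Going from 6-methoxy-5-methylpyridin-3-yl to 6-methoxy-5-(trifluoromethyl)pyridin-3-yl gives, in the phosphatidylinositol 4,5-bisphosphate 3-kinase catalytic subunit beta isoform assay, a 3.1-fold lower number from compound 1 to compound 3 (0.49 log units; beyond the scatter), so this position does respond to the change. In a physicochemical assay for solubility, read by LC-MS, measured as thermodynamic solubility, at pH 6.8 (a lower number here means a less soluble compound, a higher number a more soluble compound), compound 1 gives > 1000000 nM, which is a limit of the assay. In the physicochemical assay compound 3 gives 270000 nM. In the physicochemical assay the same change carries an at least 3.7-fold lower number from compound 1 to compound 3 (0.56 log units; beyond the scatter), a step that rests on a limit: the limit of > 1000000 nM in the physicochemical assay, at which 1 of the 2 values shown sits.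

The compounds shown leave open how another group at this position, such as chlorine, a nitrile or an ethyl, would move the numbers in the phosphatidylinositol 4,5-bisphosphate 3-kinase catalytic subunit beta isoform assay and in the physicochemical assay.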